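The compounds below may be only part of what the source reports. "The series", "measured", "known", "first", "only" and "open" are said of these compounds alone.

Three measured compounds share one core and differ only in the group carried on an amide-type nitrogen. Compound 1 `CCN(CC)CCNC(=O)c1ccc(C(CC)(CC)c2ccc(OCS(=O)(=O)c3ccccc3)c(C)c2)n1CC` carries a 2-(diethylamino)ethyl group there; in a functional assay on MCF7 cells (Homo sapiens) for antiproliferative activity, read by MTT assay, with a stated time of 24 h (on this read-out lower numbers stand for stronger inhibition and higher numbers for weaker inhibition), compound 1 gives 4680 nM. Compound 2 `CCn1c(C(=O)N[C@@H](C)CO)ccc1C(CC)(CC)c1ccc(OCS(=O)(=O)c2ccccc2)c(C)c1` carries a 1-(hydroxymethyl)ethyl group instead, and in this assay compound 2 gives 10800 nM. Compound 3 `CCn1c(C(=O)N[C@@H](CO)CCO)ccc1C(CC)(CC)c1ccc(OCS(=O)(=O)c2ccccc2)c(C)c1` carries a 3-hydroxy-1-(hydroxymethyl)propyl group, and in this assay compound 3 gives 27400 nM, the highest of the three numbers. The steps leading to it were a 5.9-fold higher number from compound 1 to compound 3 (0.77 log units; beyond the scatter) and a 2.5-fold higher number from compound 2 to compound 3 (0.40 log units; beyond the scatter), while the other step was a 2.3-fold higher number from compound 1 to compound 2 (0.36 log units; beyond the scatter).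

Compound 4 `CCn1c(C(=O)N[C@H](CC(=O)O)C(=O)O)ccc1C(CC)(CC)c1ccc(OCS(=O)(=O)c2ccccc2)c(C)c1` is not yet measured. It differs from compound 3 in one place: 1,2-dicarboxyethyl in place of 3-hydroxy-1-(hydroxymethyl)propyl on an amide-type nitrogen. Every measured step in this set is an exchange of the group on the same amide-type nitrogen, and each of them raised the number by a modest amount. Among the compounds with values here, none of them brought in a 1,2-dicarboxyethyl group, so they show only that changing the group at this position moves the number modestly. On that basis a further modest rise is expected for compound 4, as a 1.6-fold higher number from compound 3 to compound 4 (0.22 log units; within the scatter). In this assay compound 4 is estimated at 45000 nM, within a range from 15000 nM to 140000 nM.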

Compound 4, half-maximal inhibitory concentration: > 50000 nM
Compound 4: a limit, no number; the forecaster's own chance of this, stated with the estimate: 30%; middle value at least 1.1-fold (0.04 log units) from the limit.
By their numbers in this assay, from the lowest: compound 1; then compound 2; then compound 3. At a limit, above all of these: compound 4.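

Compound 4 gives no number in this assay, only a limit of the assay: the limit of > 50000 nM in this assay, at which 1 of the 4 values shown sits. Measured against its closest neighbours, the 1,2-dicarboxyethyl group gives an at least 1.8-fold higher number from compound 3 to compound 4 (0.26 log units; that floor lies within the scatter), so this comparison alone does not separate compound 4 from compound 3, whereas an at least 4.6-fold higher number from compound 2 to compound 4 (0.66 log units; beyond the scatter) and an at least 10-fold higher number from compound 1 to compound 4 (1.02 log units; beyond the scatter) both stand clear of the scatter. Within the data shown here, what the earlier compounds did not show is the reach of this position: their steps were all modest, but an exchange of the group on this amide-type nitrogen alone can now produce a large step, and the first group here with carboxylic acids gives the weakest inhibition of the set, even though its true value is unknown.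

The compounds shown leave open how a group with a single carboxylic acid, or with one of the two acids turned into a methyl ester, would behave on this nitrogen. They also leave open whether a simple primary amine or a longer chain ending in a tertiary amine would match or improve on the 2-(diethylamino)ethyl group of compound 1.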